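Moving a Methyl on a Pyridyl Sigma-1 Ligand

The source may hold more compounds than are shown below. What is called first, only, known or untested is meant among the compounds shown, and "the series" means these compounds.

Three compounds sharing one core have been measured in an assay on HEK293 cells for displacement of a labelled ligand from Sigma non-opioid intracellular receptor 1 (Homo sapiens), read by scintillation counting, with a stated time of 120 min; on this read-out lower numbers stand for stronger inhibition and higher numbers for weaker inhibition:
compound 1 `c1cn(-c2ncnc3c2cnn3CCN2CCCCC2)cn1`: 13800 nM
compound 2 `Cc1cc(F)ccc1-c1ncnc2c1cnn2CCN1CCCCC1`: 48 nM
compound 3 `Cc1ccncc1-c1ncnc2c1cnn2CCN1CCCCC1`: 707 nM

Compound 3 stands second highest of the three numbers in this assay. It sits far from the weakest, with a 20-fold lower number from compound 1 to compound 3 (1.29 log units; beyond the scatter), and also far from the strongest, with a 15-fold higher number from compound 2 to compound 3 (1.17 log units; beyond the scatter). Both of those steps swap out the whole aromatic group on the core, so they show that this group matters greatly but do not separate the effect of the methyl from that of the ring itself.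

Compound 4 `Cc1cncc(-c2ncnc3c2cnn3CCN2CCCCC2)c1` has not yet been measured. The change is 5-methylpyridin-3-yl in place of 4-methylpyridin-3-yl on an aromatic carbon. Going by the values given here, the two rings carry the same atoms, only arranged differently, so no measured step mirrors this move; the large steps of a 290-fold lower number from compound 1 to compound 2 (2.46 log units; beyond the scatter) and a 20-fold lower number from compound 1 to compound 3 (1.29 log units; beyond the scatter) concern replacing one ring by another and only set the scale of what an aromatic group can do here.

With no direct precedent, a modest step is expected for compound 4, leaning toward a higher number, shown as a 2.1-fold higher number from compound 3 to compound 4 (0.33 log units; beyond the scatter). The estimated value for compound 4 in this assay is 1500 nM, within a range of 300 nM to 7000 nM.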

Compound 4, inhibition constant: 447 nM
The estimate for compound 4 lay 3.4-fold (0.53 log units) above the measured number; measured number inside the range.
By their numbers in this assay, from the lowest: compound 2; then compounds 4 and 3 (each within the scatter of the next); then compound 1.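

Swapping 4-methylpyridin-3-yl for 5-methylpyridin-3-yl gives a 1.6-fold lower number from compound 3 to compound 4 (0.20 log units; within the scatter) in this assay, so these two arrangements of the same atoms cannot be told apart, and the place of the methyl on this pyridine ring shows no clear effect here. The steps that exchange the whole aromatic group, a 9.3-fold higher number from compound 2 to compound 4 (0.97 log units; beyond the scatter) and a 31-fold lower number from compound 1 to compound 4 (1.49 log units; beyond the scatter), both stay beyond the scatter, so for these four compounds the identity of the aromatic group on the shared core is what separates the numbers, and the new isomer confirms that the gaps seen with compound 3 do not depend on that one methyl arrangement. The data shown offer no measurement that could explain why moving the methyl leaves the number within the scatter.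

Whether the methyl contributes anything at all remains open, as a plain pyridin-3-yl ring with no methyl is not among the compounds shown. Also open, on these data alone, is how this ring would respond to a larger group in the same place, such as an ethyl or a methoxy group, or to a 4-fluorophenyl group lacking the methyl of compound 2.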